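From nitro to hydroxy on a shared core

The compounds below may be only part of what the source reports. "The series", "measured", "known", "first", "only" and "open" are said of these compounds alone.

Compound 1 `COc1ccc(/C=C/C(=O)/C=C/c2nc3cc(C)ccc3n2C)cc1O` gives 7700 nM
Compound 2 `COc1ccc(/C=C/C(=O)/C=C/c2nc3cc([N+](=O)[O-])ccc3n2C)cc1O` gives 10500 nM

Among the compounds with values here, in a functional assay on NCI-H460 cells (Homo sapiens) for cytotoxicity, read by MTT assay, with a stated time of 48 h (a higher number here means a weaker inhibitor, a lower number a stronger inhibitor), compound 2 at 10500 nM cannot be told apart from compound 1, the only other compound measured so far. Compound 3 `COc1ccc(/C=C/C(=O)/C=C/c2nc3cc(O)ccc3n2C)cc1O` carries hydroxy in place of nitro on an aromatic carbon. Within the data shown here, the only measured step that bears on this is nitro in place of methyl on an aromatic carbon (a 1.4-fold higher number from compound 1 to compound 2 (0.13 log units; within the scatter)), which stayed within the scatter. That single step is a thin guide, but in this assay no change beyond the scatter is expected. The expected step is small (a 1.3-fold lower number from compound 2 to compound 3 (0.12 log units; within the scatter)). For compound 3 the estimate is 8000 nM with an expected range from 3500 nM to 18000 nM as the likely span.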

Compound 3, half-maximal inhibitory concentration: 7200 nM
Estimate against measurement, compound 3: 1.1-fold (0.05 log units) above, and the stated range covers the measured number.
By their numbers in this assay, from the lowest: compounds 3, 1 and 2 (each within the scatter of the next).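

In this assay this aromatic carbon has now carried methyl, nitro and hydroxy, and the new group gives a 1.5-fold lower number from compound 2 to compound 3 (0.16 log units; within the scatter) and a 1.1-fold lower number from compound 1 to compound 3 (0.03 log units; within the scatter) with both steps inside the scatter. Hydroxy brings a hydrogen-bond donor where nitro had none, yet the number does not move beyond the scatter. Nothing measured here says why these groups read alike. On these data alone, whether an amine, a carboxylic acid or a longer chain on this carbon would move the number beyond the scatter stays open.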